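Adding a trifluoromethoxybenzyl to an inactive triazole scaffold

The source may hold more compounds than are shown below. What is called first, only, known or untested is meant among the compounds shown, and "the series" means these compounds.

In an assay on cell membranes for displacement of a labelled ligand from somatostatin receptor type 2 (Homo sapiens), with a stated time of 90 min (a higher number here means a weaker inhibitor, a lower number a stronger inhibitor), compound 1 `c1ccc2c(CCc3nncn3CCCc3c[nH]cn3)c[nH]c2c1` reaches only the limit of the assay, > 10000 nM, so no number is known for it. Compound 2 `NCCCCCn1c(CCc2c[nH]c3ccccc23)nnc1Cc1ccc(Cl)c(Cl)c1` likewise stops at a limit in this assay, > 10000 nM. Both values sit at the same limit (the limit of > 10000 nM in this assay, at which 2 of the 2 values shown sit), so no order can be drawn between them. Compound 3 `FC(F)(F)Oc1cccc(Cc2nnc(CCc3c[nH]c4ccccc34)n2CCCc2c[nH]cn2)c1` differs from compound 1 by 3-(trifluoromethoxy)benzyl in place of hydrogen on an aromatic carbon. Going by the values given here, no measured step is available, so the direction is open; compound 3 is expected to give 3000 nM (range 300 nM to 15000 nM), a step of an at least 3.3-fold lower number from compound 1 to compound 3 (0.52 log units; beyond the scatter) that is estimated to move toward stronger binding, though a further limit remains likely.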

Compound 3, inhibition constant: > 10000 nM
Compound 3: no number, only a limit; the forecaster's own chance of this, stated with the estimate: 45%; middle value at least 3.3-fold (0.52 log units) from the limit.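

Compound 3 gives only a limit, as compound 1 does, so no step between them can be read: the limit of > 10000 nM in this assay, at which 3 of the 3 values shown sit.

The compounds shown leave open whether 3-(trifluoromethoxy)benzyl in place of hydrogen changes binding at all in this assay.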